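Removing the tetrazole methyl: compound 1 to compound 4

The source may hold more compounds than are shown below. What is called first, only, known or untested is meant among the compounds shown, and "the series" means these compounds.

Measured compounds:
compound 1 `Cn1nnc(-c2sc(-c3cccc(F)c3)nc2O)n1` — 214 nM
compound 2 `CCOC(=O)c1sc(-c2ccccc2)nc1N` — > 100000 nM
compound 3 `CCn1nnc(-c2sc(-c3cccc(O)c3)nc2O)n1` — 239 nM

In an assay on HEK293 cells for inhibition of transient receptor potential cation channel subfamily M member 8 (Homo sapiens), read by FLIPR, with stated times of 5 min and 3 min (a higher number here means a weaker inhibitor, a lower number a stronger inhibitor), compound 1 gives 214 nM, the lowest of the two numbers shown. Compound 3 gives 239 nM in the same assay, which lies within the scatter of compound 1, so the two cannot be told apart. For compound 2 the assay reports only a limit, > 100000 nM, and no number (the limit of > 100000 nM in this assay, at which 1 of the 3 values shown sits).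

Compound 4 `Oc1nc(-c2cccc(F)c2)sc1-c1nn[nH]n1` has not yet been measured. It differs from compound 1 in a single place: hydrogen in place of methyl on an aromatic nitrogen. Among the compounds with values here, no step between two measured compounds is available to size this change, so the expectation rests on the structural change alone. The step of a 3.7-fold higher number from compound 1 to compound 4 (0.57 log units; beyond the scatter) is expected to run toward a higher number, a weaker inhibitor, and to exceed the scatter. Compound 4 is accordingly estimated at 800 nM, with a range from 200 nM to 4000 nM.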

Compound 4, half-maximal inhibitory concentration: > 100000 nM
Compound 4 gave a limit, no number (the forecaster's own chance of this, stated with the estimate: 5%); middle value at least 120-fold (2.09 log units) away from the limit.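

The earlier compounds shown here offered no step at this position, so the methyl of the 2-methyl-2H-tetrazol-5-yl group could not be sized. In this assay, the change to 2H-tetrazol-5-yl, with hydrogen in place of methyl on an aromatic nitrogen, now gives an at least 460-fold higher number from compound 1 to compound 4 (2.66 log units; beyond the scatter), which shows that this single heavy atom matters greatly with the rest of compound 1 held constant. Compound 4 gives a limit and not a number, the same limit as the unrelated compound 2: the limit of > 100000 nM in this assay, at which 2 of the 4 values shown sit.

The compounds shown leave open whether a propyl chain or a cyclopropyl ring on this nitrogen would keep the activity of compound 1 or improve on it. They also leave open whether the ethyl group of compound 3 differs from methyl, since compound 3 also differs from compound 1 on its phenyl ring.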